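Compound 3: methyl in place of chloro on the ring

This account rests on a few compounds, and the source may have more. Where it says the series, first, only, none or still open, it means among the compounds named here.

Measured so far in an assay on isolated protein for inhibition of Monoamine oxidase (Rattus norvegicus); a higher number here means a weaker inhibitor, a lower number a stronger inhibitor: compound 1 `C=C=C(CN)Cc1ccccc1` gives 140 nM; compound 2 `C=C=C(CN)Cc1ccc(Cl)cc1` gives 40 nM.

Compound 2 stands lowest of the two numbers, with compound 1 nearest after the step of a 3.5-fold lower number from compound 1 to compound 2 (0.54 log units; beyond the scatter). Compound 3 `C=C=C(CN)Cc1ccc(C)cc1` differs from compound 2 by methyl in place of chloro on an aromatic carbon. Among the measured compounds shown here, the only step that bears on this is a 3.5-fold lower number from compound 1 to compound 2 (0.54 log units; beyond the scatter); it shows what chloro is worth against hydrogen, and methyl is neither, so a number between the two is expected, a small rise from compound 2. Compound 3 is estimated at 70 nM, range 30 nM to 160 nM. That estimate means a step of a 1.8-fold higher number from compound 2 to compound 3 (0.24 log units; within the scatter).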

Compound 3, half-maximal inhibitory concentration: 360 nM
Estimate against measurement, compound 3: 5.1-fold (0.71 log units) below; measured number above the stated range.
By their numbers in this assay, from the lowest: compound 2; then compound 1; then compound 3.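

At this position, adding a group does not by itself lower the number: in this assay methyl in place of hydrogen goes the opposite way to chloro (a 2.6-fold higher number from compound 1 to compound 3 (0.41 log units; beyond the scatter)). Methyl in place of chloro gives the largest step in the series so far (a 9.0-fold higher number from compound 2 to compound 3 (0.95 log units; beyond the scatter)), so the gain in compound 2 is specific to chloro, not shared by any single heavy atom placed there. Nothing at hand accounts for the difference between the two groups.

From the compounds shown here alone, whether fluoro, methoxy or an amine at this position would track chloro or methyl remains open. Also open, going by these compounds, is whether chloro elsewhere on the ring keeps the gain.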